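The source may report more compounds than this note shows. Statements on the series, on what has been measured and on what is new or still open speak of the compounds shown alone.

Of the compounds shown here, three have so far been tested in a functional assay on the whole organism (artery, strain albino) with Rattus norvegicus as the target, with a stated time of 300 min, at a dose of 10 mg/kg by the oral route; a lower number here means less inhibition, a higher number more inhibition at the dose given (going by the name of the read-out). Compound 1 `COc1ccc(C2N=C(SCc3ccc(Cl)cc3)NC(C)=C2C(=O)Nc2ccc(Br)cc2)cc1` gives 37.9% in this assay. Compound 2 `COc1ccc(C2N=C(SCc3ccc(F)cc3)NC(C)=C2C(=O)Nc2ccc(Br)cc2)cc1` differs from compound 1 in one place, (fluoro in place of chloro on an aromatic carbon), and in this assay compound 2 gives 26.2%. That single swap gives the step of a number 11.7 percentage points lower from compound 1 to compound 2 (beyond the scatter). Compound 3 `CC1=C(C(=O)Nc2ccc([N+](=O)[O-])cc2)C(c2ccc(Br)cc2)N=C(SCc2ccc(Cl)cc2)N1` is built on a different core; the difference between the core of compound 1 and the core of compound 3 is not broken down here. In this assay compound 3 gives 37.9%, which lies level with compound 1, the two of them together giving the highest of the three numbers.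

Compound 4 `CC1=C(C(=O)Nc2ccc([N+](=O)[O-])cc2)C(c2ccc(Br)cc2)N=C(SCc2ccc(F)cc2)N1` has not yet been measured. Within the data shown here, it differs from compound 3 in one place, (fluoro in place of chloro on an aromatic carbon), and this is the same change as the one between compound 1 and compound 2. Among the measured compounds shown here, only one measured pair shows this change, so any expectation rests on that pair alone and on how the two cores are read. The step from compound 3 to compound 4 is expected to be a number 11.9 percentage points lower from compound 3 to compound 4 (beyond the scatter), resting on the measured step of a number 11.7 percentage points lower from compound 1 to compound 2 (beyond the scatter). Compound 4 is therefore expected to give about 26% in this assay. For compound 4 the value is expected to fall in an estimated range from 14% to 38%, a range that allows for the usual scatter of such measurements and for the fact that a single pair is a thin basis.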

Compound 4, a percentage reported as inhibition, in the whole organism at one dose (the size of the read-out at that dose, not a potency): 34.4%
Compound 4: the middle estimate sits 8.4 percentage points below what was measured, and the stated range covers the measured number.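

In this assay, the change from 4-chlorobenzyl to 4-fluorobenzyl on the core of compound 3 gives a number 3.5 percentage points lower from compound 3 to compound 4 (within the scatter), so on this core the effect of the swap cannot be told apart from the ordinary spread of repeated measurements, whereas on the core of compound 1 its step lay beyond that spread. Set side by side, the two steps do not differ by more than such measurements can account for: the same change on two cores in this assay, a number 11.7 percentage points lower (beyond the scatter) from compound 1 to compound 2 and a number 3.5 percentage points lower (within the scatter) from compound 3 to compound 4, 8.2 percentage points apart, within the scatter of two such steps This means the change can be carried from one core to the other with no demonstrable difference in its effect, but it does not show that the step is the same size on both cores, or that it is a real effect on the core of compound 3, and two pairs are too few to rule out an influence of the core.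

The compounds shown leave open what would happen with an amine or a carboxylic acid in place of the chloro or fluoro, or with a longer chain in place of the benzyl group. They also leave open whether the same picture would hold at other doses, since each number here describes a single oral dose and is not a potency.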